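A few compounds are considered here, and "the series" means these few. Any claim that something is new, unique, unknown or untested is made for them only; others in the source may bear on it.

Compound 1 `COc1ccc(N/C(CCNC2=CC(=O)c3ccccc3C2=O)=N\S(=O)(=O)c2ccc(C)cc2)cc1`: 6030 nM
Compound 2 `COc1ccc(N/C(CCNC2=CC(=O)c3ccccc3C2=O)=N\S(=O)(=O)c2ccc(C)cc2)c(OC)c1`: 30200 nM

In a functional assay on MCF7 cells (Homo sapiens) for cytotoxicity, read by MTT assay, with a stated time of 48 h (a higher number here means a weaker inhibitor, a lower number a stronger inhibitor), compound 2 gives 30200 nM, the higher of the two numbers. Going by the values given here, its only neighbour, compound 1, gives 6030 nM, and the step of a 5.0-fold higher number from compound 1 to compound 2 (0.70 log units; beyond the scatter) lies beyond the scatter. Compound 3 `Cc1ccc(S(=O)(=O)/N=C(/CCNC2=CC(=O)c3ccccc3C2=O)NC2CCCCC2)cc1` has not yet been measured in this assay. It differs from compound 2 by cyclohexyl in place of 2,4-dimethoxyphenyl on an amine nitrogen. Among the compounds with values here, the one measured step concerns a methoxy on an aromatic carbon rather than the exchange of an aromatic ring for a non-aromatic one, so it bears on the change only loosely; it does show that this part of the molecule moves the numbers beyond the scatter. Because the step of a 5.0-fold higher number from compound 1 to compound 2 (0.70 log units; beyond the scatter) went upward when a methoxy was added, a return to lower numbers is expected once both methoxy groups are gone, and the expected step of a 3.0-fold lower number from compound 2 to compound 3 (0.48 log units; beyond the scatter) is modest. Compound 3 is therefore estimated at 10000 nM, within a range from 2500 nM to 40000 nM.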

Compound 3, half-maximal inhibitory concentration: 7580 nM
For compound 3 the middle estimate is 1.3-fold (0.12 log units) above the measured one, within the range that was stated.
By their numbers in this assay, from the lowest: compounds 1 and 3 (each within the scatter of the next); then compound 2.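

In this assay the step of a 1.3-fold higher number from compound 1 to compound 3 (0.10 log units; within the scatter) shows that this amine nitrogen can carry a non-aromatic ring of carbon only in place of 4-methoxyphenyl, with the two numbers not distinguishable. The step of a 4.0-fold lower number from compound 2 to compound 3 (0.60 log units; beyond the scatter) sets cyclohexyl apart from 2,4-dimethoxyphenyl, so among these three compounds the high number belongs to compound 2 alone, and an aromatic ring at this place does not by itself go with either a high or a low number. No available measurement accounts for these steps.

The compounds shown leave open how the number would respond at this nitrogen to a group with no ring at all, such as a methyl or a longer alkyl chain. They also leave open what a hydroxyl or an amine on the cyclohexyl ring would do.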